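The source may hold more compounds than are shown below. What is called first, only, known or untested is meant among the compounds shown, and "the series" means these compounds.

Measured in an assay on isolated protein for agonist activity at Bile acid receptor (Homo sapiens), read by AlphaScreen, with a stated time of 30 min; a higher number here means that more compound is needed for the effect, a lower number that less compound is needed:
- compound 1 `Cc1nn(-c2ccccc2C(F)(F)F)c2c1C(c1ccc(Oc3ccccc3)cc1)SC(C)C(=O)N2`: 2000 nM
- compound 2 `Cc1ccccc1-n1nc(C)c2c1NC(=O)[C@H](C)S[C@@H]2c1ccc(-c2ccsc2)cc1`: 1400 nM
- compound 3 `COc1ccccc1-c1ccc([C@H]2S[C@@H](C)C(=O)Nc3c2c(C)nn3-c2ccccc2C)cc1`: 1100 nM

Compound 3 gives the lowest of the three numbers, yet neither neighbour is separated from it beyond the scatter: the step of a 1.3-fold lower number from compound 2 to compound 3 (0.10 log units; within the scatter) is within the scatter, and the number of compound 1 lies within the scatter of that of compound 3 as well. The three measured compounds are therefore best read as one cluster.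

Compound 4 `Cc1ccccc1-n1nc(C)c2c1NC(=O)[C@H](C)S[C@@H]2c1ccc(Oc2ccccc2)cc1` is the next member. Its change from compound 3: phenoxy in place of 2-methoxyphenyl on an aromatic carbon. Within the data shown here, the only measured step at this position, a 1.3-fold lower number from compound 2 to compound 3 (0.10 log units; within the scatter), exchanged one aryl group for another and stayed within the scatter. Compound 1 carries phenoxy at the same position but differs from compound 4 in the group on the core as well, so its number only shows that a phenoxy-bearing analogue sits in the same cluster. On this basis no step beyond the scatter is expected for a 1.4-fold higher number from compound 3 to compound 4 (0.13 log units; within the scatter). Compound 4 is estimated at 1500 nM, with a range of 600 nM to 4000 nM.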

Compound 4, half-maximal effective concentration: 1300 nM
Compound 4: middle estimate off by 1.2-fold (0.06 log units), on the high side, within the range that was stated.
By their numbers in this assay, from the lowest: compounds 3, 4, 2 and 1 (each within the scatter of the next).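

In this assay, phenoxy brings an oxygen link into this position, on an aromatic carbon para to a large group, where the earlier measured step had only exchanged one directly attached aryl group for another. The link produces no step beyond the scatter: a 1.2-fold higher number from compound 3 to compound 4 (0.07 log units; within the scatter) and a 1.1-fold lower number from compound 2 to compound 4 (0.03 log units; within the scatter). Thiophen-3-yl, 2-methoxyphenyl and phenoxy therefore read as interchangeable here on the numbers for compounds 2, 3 and 4, and no information is available to explain this.

As far as these compounds go, all three groups carry an aromatic ring, so it remains open whether an amine, a carboxylic acid or a longer alkyl chain at this position would move the number beyond the scatter. From the compounds shown here alone, it is also open whether the same flat picture holds when the shared core carries other groups.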